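Cytotoxicity Holds at the Limit Across Four Analogues

A few compounds are considered here, and "the series" means these few. Any claim that something is new, unique, unknown or untested is made for them only; others in the source may bear on it.

Measured so far:
Compound 1, `COc1nc(-c2ccc(Br)cc2)ccc1[C@@H](c1ccccc1)[C@@](O)(CCN(C)C)c1cccc2ccccc12`: in a toxicity assay on HeLa cells (Homo sapiens) for cytotoxicity (a higher number here means that more compound is tolerated, a lower number that less compound is tolerated), compound 1 gives > 64 ug/mL, a limit of the assay rather than a number.
Compound 2, `COc1ccc(-c2ccc([C@@H](c3ccccc3)[C@@](O)(CCN(C)C)c3cccc4ccccc34)c(OC)n2)cc1`: compound 2 gives > 64 ug/mL, again only a limit.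
Compound 3, `COc1nc(-c2ccc(OC(F)(F)F)cc2)ccc1[C@@H](c1ccccc1)[C@@](O)(CCN(C)C)c1cccc2ccccc12`: compound 3 gives > 64 ug/mL, also a limit.

Compound 3 therefore stands exactly where its two neighbours stand, at the ceiling of what was tested. The steps a step that the two limits leave unreadable from compound 1 to compound 3 and a step that the two limits leave unreadable from compound 2 to compound 3 cannot be sized because all three values sit at the limit of > 64 ug/mL in this assay, at which 3 of the 3 values shown sit. Compound 4, `COc1nc(-c2ccc(Cl)c(F)c2)ccc1[C@@H](c1ccccc1)[C@@](O)(CCN(C)C)c1cccc2ccccc12`, differs from compound 3 by 4-chloro-3-fluorophenyl in place of 4-(trifluoromethoxy)phenyl on an aromatic carbon. Within the data shown here, no measured step shows any cytotoxicity appearing, so the expected step that the limit leaves unreadable from compound 3 to compound 4 is none beyond the scatter. Compound 4 is estimated at 70 ug/mL, between 40 ug/mL and 130 ug/mL. A report of only a limit is the likelier outcome.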

Compound 4, half-maximal cytotoxic concentration: > 64 ug/mL
Compound 4 was reported as a limit; the forecaster's own chance of this, stated with the estimate: 80%; the middle value lies beyond the limit too.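

In this assay, among these compounds, compound 4 gives only a limit, as do compound 1, compound 2 and compound 3, so no step among them can be read: the limit of > 64 ug/mL in this assay, at which 4 of the 4 values shown sit. From the compounds shown here alone, at what concentration any of these four compounds would become cytotoxic stays open.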